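The compounds below may be only part of what the source reports. "The series", "measured", "known", "first", "only" and "open" are said of these compounds alone.

Measured compounds:
compound 1, `N#C/C(=C\c1c(-c2ccccc2)[nH]c2ccccc12)C(=O)c1ccccc1`: 2500 nM
compound 2, `COc1ccc(-c2[nH]c3ccc(OC)cc3c2/C=C(\C#N)S(=O)(=O)c2ccccc2)cc1`: 4200 nM

Both numbers come from a functional assay on CAKI-1 cells (Homo sapiens) for inhibition, read by sulforhodamine B assay, with a stated time of 48 h; on this read-out lower numbers stand for stronger inhibition of growth and higher numbers for weaker inhibition of growth. In this assay compound 1 gives 2500 nM and compound 2 gives 4200 nM; the two values lie within the usual scatter of each other, so compound 1 is not set apart from compound 2 on what has been measured. Compound 3, `N#C/C(=C\c1c(-c2ccccc2)[nH]c2ccccc12)S(=O)(=O)c1ccccc1`, has not yet been measured. It differs from compound 1 in one place: phenylsulfonyl in place of benzoyl on a double-bonded chain carbon bound to a double-bonded chain carbon and a triple-bonded carbon. Within the data shown here, no step between two measured compounds isolates this change, and compound 2, which also carries a phenylsulfonyl group, differs from compound 1 in further places, so its value shows only that such a compound lands in the same region. Compound 3 is expected to show a 1.2-fold higher number from compound 1 to compound 3 (0.08 log units; within the scatter), a step no larger than the scatter. The estimate for compound 3 is 3000 nM, with a range from 1200 nM to 8000 nM.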

Compound 3, concentration for 50% growth inhibition: 5500 nM
Estimate against measurement, compound 3: 1.8-fold (0.26 log units) below, within the range that was stated.
By their numbers in this assay, from the lowest: compounds 1, 2 and 3 (each within the scatter of the next, the first and the last beyond it).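

Replacing benzoyl with phenylsulfonyl on a double-bonded chain carbon bound to a double-bonded chain carbon and a triple-bonded carbon gives a 2.2-fold higher number from compound 1 to compound 3 (0.34 log units; beyond the scatter) in this assay, a modest step but one beyond the scatter. The earlier compounds shown here had no step that isolated this change, and this one shows that, on the core of compound 1, the position is sensitive to the exchange, with benzoyl giving the lower number and so the stronger inhibition of growth. No measurement shown here accounts for this step.

On these data alone, whether a carboxylic acid, an ester or an amide at this position would give a lower number than benzoyl remains open. Also open, as far as these compounds go, is whether the same exchange would give a step of similar size on the core of compound 2.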